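Working notes: compound 4 against the three measured compounds

The source may report more compounds than this note shows. Statements on the series, on what has been measured and on what is new or still open speak of the compounds shown alone.

Measured in a functional assay for antagonist activity at Neuropeptide Y receptor type 2 (Homo sapiens); on this read-out higher numbers stand for weaker inhibition and lower numbers for stronger inhibition:
- compound 1 `CCCc1ccc(NC(=S)N2CCC(C(O)(c3ccccc3)c3ccccc3)CC2)cc1`: 777 nM
- compound 2 `CCOc1ccc(NC(=S)N2CCC(C(O)(c3ccccc3)c3ccccc3)CC2)cc1C#N`: 323 nM
- compound 3 `COc1ccc(OC(=O)N2CCC(C(O)(c3ccccc3)c3ccccc3)CC2)cc1`: 2680 nM

Compound 3 stands at the highest of the three numbers. For the measured compounds named here, compound 1 is the nearest to it, compound 2 the furthest, and both gaps lie beyond the scatter; the one step measured within a single change is a 2.4-fold lower number from compound 1 to compound 2 (0.38 log units; beyond the scatter), a modest lowering.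

Compound 4 `O=C(Oc1ccc(S(=O)(=O)N2CCCC2)cc1)N1CCC(C(O)(c2ccccc2)c2ccccc2)CC1` differs from compound 3 in one place: (pyrrolidin-1-yl)sulfonyl in place of methoxy on an aromatic carbon. Going by the values given here, no measured step follows the same change. Among the compounds with values here, the only step with any bearing, the one from compound 1 to compound 2, concerns a different group on a different part of the shared core and was modest, so it gives direction more than size. The expectation for compound 4 is therefore a modest lowering, a 2.2-fold lower number from compound 3 to compound 4 (0.35 log units; beyond the scatter), with wide uncertainty. For compound 4 in this assay the estimate is 1200 nM, within a range from 400 nM to 4000 nM.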

Compound 4, half-maximal inhibitory concentration: 49 nM
The estimate for compound 4 lay 24-fold (1.39 log units) above the measured number, and the stated range ends above it.
By their numbers in this assay, from the lowest: compound 4; then compound 2; then compound 1; then compound 3.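

In this assay, the aromatic carbon para to a large group accepts a much bigger substituent than the methoxy of compound 3: (pyrrolidin-1-yl)sulfonyl there gives a 55-fold lower number from compound 3 to compound 4 (1.74 log units; beyond the scatter) as a large step. For the compounds shown here, the only earlier single-place step, a 2.4-fold lower number from compound 1 to compound 2 (0.38 log units; beyond the scatter), was modest and lay on a different part of the shared core. Here, 8 heavy atoms and a five-membered non-aromatic ring replace 2 heavy atoms without any loss on this read-out, and nothing available explains the size of the step.

As far as these compounds go, it remains open whether the sulfonyl unit or the pyrrolidine ring carries the step, which methylsulfonyl or dimethylaminosulfonyl at this place would help separate. A piperidine ring on the sulfonyl would test how much ring size matters.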